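The compounds below may be only part of what the source reports. "The series", "measured", "known", "first", "only" and "open" are said of these compounds alone.

Measured so far in an ADME assay on BHK-21 cells (Mesocricetus auratus) for cytotoxicity, read by MTT assay, with a stated time of 72 h; on this read-out higher numbers stand for lower toxicity in this test and lower numbers for higher toxicity in this test:
compound 1 `Cc1cccc(C2CC(c3ccc(Oc4ccccc4)cc3)=NN2c2ccc(S(N)(=O)=O)cc2)c1` gives 8000 nM
compound 2 `Cc1cccc(C2CC(c3ccccc3)=NN2c2ccc(S(N)(=O)=O)cc2)c1` gives 25000 nM
compound 3 `Cc1ccccc1C1CC(c2ccc(Oc3ccccc3)cc2)=NN1c1ccc(S(N)(=O)=O)cc1` gives 7000 nM

Compound 4 `Cc1ccccc1C1CC(c2ccccc2)=NN1c1ccc(S(N)(=O)=O)cc1` is not yet measured in this assay. It is reached from compound 3 by the change (hydrogen in place of phenoxy on an aromatic carbon). The same change has been made once before among these compounds, from compound 1 to compound 2, where it produced a 3.1-fold higher number from compound 1 to compound 2 (0.49 log units; beyond the scatter). The cores on which the change is made differ from each other as given by 2-methylphenyl in place of 3-methylphenyl on a saturated ring carbon; that difference, from compound 1 to compound 3, gave a 1.1-fold lower number from compound 1 to compound 3 (0.06 log units; within the scatter), so the two parent compounds stand close together in this assay. The place of the change is described in the same words for both pairs, so the change from compound 3 to compound 4 is the same one as from compound 1 to compound 2. Compound 3 and compound 2 lie furthest apart among the three measured compounds, a difference beyond the scatter.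

Among the measured compounds shown here, with only one earlier instance of this change, the step into compound 4 is expected to be of about the same size as the earlier one; the expected step is a 3.1-fold higher number from compound 3 to compound 4 (0.50 log units; beyond the scatter), which rests on the single observed instance a 3.1-fold higher number from compound 1 to compound 2 (0.49 log units; beyond the scatter) and on the closeness of the two parents. Compound 4 is accordingly estimated at 22000 nM, with a likely range from 10000 nM to 45000 nM. A limit rather than a number is considered unlikely for compound 4.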

Compound 4, half-maximal cytotoxic concentration: 14000 nM
The estimate for compound 4 lay 1.6-fold (0.20 log units) above the measured number; low and high end bracket the measured number.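

In this assay, hydrogen in place of phenoxy gives a 2.0-fold higher number from compound 3 to compound 4 (0.30 log units; within the scatter), and this step agrees with the earlier one on the other core: the same change on two cores in this assay, a 3.1-fold higher number (0.49 log units; beyond the scatter) from compound 1 to compound 2 and a 2.0-fold higher number (0.30 log units; within the scatter) from compound 3 to compound 4, 1.6-fold (0.19 log units) apart, within the scatter of two such steps. Seen from the other side of the same square, 2-methylphenyl in place of 3-methylphenyl gives a 1.8-fold lower number from compound 2 to compound 4 (0.25 log units; within the scatter) with hydrogen in the place of phenoxy, and this step agrees with the one measured with phenoxy present: the same change on two cores in this assay, a 1.1-fold lower number (0.06 log units; within the scatter) from compound 1 to compound 3 and a 1.8-fold lower number (0.25 log units; within the scatter) from compound 2 to compound 4, 1.6-fold (0.19 log units) apart, within the scatter of two such steps. The four compounds therefore show the phenoxy change carrying over between these two cores with no detectable dependence on the methylphenyl group, but they do not show a general rule: the two cores differ only in that one group, and the step on compound 3 taken alone stays within the scatter, so it adds agreement rather than a second clear rise in the number.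

As far as these compounds go, it remains open whether the same step would appear on a core with something other than a methyl on that aryl group, such as an amine or a carboxylic acid. Also open, from the compounds shown here alone, is how groups other than phenoxy and hydrogen at this place, such as a methoxy group or a longer chain, would read in this assay.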